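The compounds below may be only part of what the source reports. "The series", "measured", "known", "first", "only" and "open" are said of these compounds alone.

In a functional assay on MCF7 cells (Homo sapiens) for antiproliferative activity, read by sulforhodamine B assay, with a stated time of 72 h (on this read-out lower numbers stand for stronger inhibition and higher numbers for weaker inhibition), compound 1 (`Fc1ccc(/C=C\c2cc3ccccc3nc2Cl)cc1`) gives 20300 nM and compound 2 (`COc1ccc2nc(Cl)c(/C=C\c3ccc(C(F)(F)F)cc3)cc2c1`) gives 12400 nM. These two values lie within the usual scatter of repeated measurements, so the numbers cannot separate compound 2 from compound 1, and both are single data points on a small scale of evidence. Compound 3 (`COc1ccc2nc(Cl)c(/C=C\c3ccc(F)cc3)cc2c1`) is compound 2 with one change: fluoro in place of trifluoromethyl on an aromatic carbon, para to a large group (fluoro in place of trifluoromethyl on an aromatic carbon). Among the compounds with values here, no measured step shows what this swap does on its own, so the expectation rests on thin evidence. Compound 1 also carries a fluoro group and gives 20300 nM, a value close to that of compound 2, so no step beyond the scatter is expected in this assay. Compound 3 is estimated at 14000 nM, with an expected range of 6000 nM to 30000 nM.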

Compound 3, half-maximal inhibitory concentration: 8970 nM
The estimate for compound 3 lay 1.6-fold (0.19 log units) above the measured number; the measured number falls inside the stated range.
By their numbers in this assay, from the lowest: compounds 3, 2 and 1 (each within the scatter of the next, the first and the last beyond it).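

In this assay, putting fluoro in place of trifluoromethyl on this aromatic carbon gives a 1.4-fold lower number from compound 2 to compound 3 (0.14 log units; within the scatter) and stays within the scatter, so one heavy atom in place of four leaves the number unresolved from that of compound 2. Methoxy in place of hydrogen on an aromatic carbon of the core gives a 2.3-fold lower number from compound 1 to compound 3 (0.35 log units; beyond the scatter) and is a modest step beyond the scatter, the only single change here that separates two compounds. No measurement shown offers a reason for either step.

From the compounds shown here alone, whether an amine or a carboxylic acid on this same aromatic carbon would keep the number in this range remains open. Also open, going by these compounds, are whether a longer chain in place of methoxy would go further, and whether methoxy has the same effect when trifluoromethyl is the group on the other ring.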